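Methoxy for Chloro: Solubility Outlook for Compound 3

This account rests on a few compounds, and the source may have more. Where it says the series, first, only, none or still open, it means among the compounds named here.

Compound 1, with the structure `CC(C)Nc1nc(NCc2ccco2)c2c(Cl)cccc2n1`, has been tested in a physicochemical assay for solubility, at pH 7.4; a lower number here means a less soluble compound, a higher number a more soluble compound. In this assay compound 1 gives <= 10000 nM, which is a limit of the assay rather than a measured number, so where compound 1 truly stands is known only as the limit of <= 10000 nM in this assay, at which 1 of the 2 values shown sits. Compound 2, `Cc1ccc2nc(NC(C)C)nc(NCc3ccco3)c2c1`, shares the same core but carries a methyl group in place of the chloro. In this assay compound 2 gives <= 20000 nM, again a limit and not a number, as stated in the limit of <= 20000 nM in this assay, at which 1 of the 2 values shown sits. Among the compounds with values here, because both results are limits, no step between the two measured compounds can be sized, and no pattern can be drawn from them.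

Compound 3, `COc1cccc2nc(NC(C)C)nc(NCc3ccco3)c12`, is not yet measured. It differs from compound 1 by methoxy in place of chloro on an aromatic carbon. Within the data shown here, with no measured step to lean on, the expected change from compound 1 to compound 3 is estimated as an at least 1.5-fold higher number from compound 1 to compound 3 (0.17 log units; that floor lies within the scatter), a shift within or only slightly beyond the usual scatter. Compound 3 is therefore expected to give about 15000 nM, somewhere between 4000 nM and 50000 nM.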

Compound 3, solubility: <= 20000 nM
Compound 3: no number, only a limit; the forecaster's own chance of this, stated with the estimate: 50%; the middle value does not contradict the limit.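

In this assay compound 3 gives <= 20000 nM, which is a limit of the assay and not a number. Compound 1 also has only a limit, so no step can be read between compound 1 and compound 3. Still open, from the compounds shown here alone, is where each truly stands in this assay, and whether methoxy in place of chloro changes the read-out at all.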